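The source may hold more compounds than are shown below. What is called first, only, known or untested is meant among the compounds shown, and "the series" means these compounds.

In a functional assay on T29Kt1 cells (Homo sapiens) for cytotoxicity, read by sulforhodamine B assay, with a stated time of 3 days (on this read-out higher numbers stand for weaker inhibition and lower numbers for stronger inhibition), compound 1 `OCc1cn(Cc2ccc(Cl)cc2)c2ccccc12` gives 79 nM and compound 3 `CC(O)c1cn(Cc2ccc(Cl)cc2)c2ccccc12` gives 19900 nM as the higher of the two plain numbers here. The gap to its nearest neighbour is a 250-fold higher number from compound 1 to compound 3 (2.40 log units; beyond the scatter) and lies well beyond the scatter. Compound 2 `OCCc1cn(Cc2ccc(Cl)cc2)c2ccccc12` reads > 31600 nM here, and that is a limit of the assay.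

The next structure is compound 4 `COCc1cn(Cc2ccc(Cl)cc2)c2ccccc12`. The change is methoxymethyl in place of 1-hydroxyethyl on an aromatic carbon in short, methoxymethyl in place of 1-hydroxyethyl on an aromatic carbon, with the same atoms joined differently.

Going by the values given here, no measured step tests a methoxymethyl group directly, but three steps concern the group on this aromatic carbon. Two are large, an at least 400-fold higher number from compound 1 to compound 2 (2.60 log units; beyond the scatter) and a 250-fold higher number from compound 1 to compound 3 (2.40 log units; beyond the scatter), so among these compounds, leaving the group of compound 1 has been costly each time. The third, an at least 1.5-fold lower number from compound 2 to compound 3 (0.20 log units; that floor lies within the scatter), has a floor within the scatter, so exchanging one altered chain for another has shown no clear effect so far.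

On that basis, compound 4 is expected to stay close to compound 3 rather than return towards compound 1. The step expected in this assay is a 1.7-fold lower number from compound 3 to compound 4 (0.22 log units; within the scatter) and so no shift beyond the scatter. For compound 4 the estimate is 12000 nM with an expected range from 800 nM to 31600 nM in this test.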

Compound 4, half-maximal inhibitory concentration: 7940 nM
Compound 4: the middle estimate sits 1.5-fold (0.18 log units) above what was measured, within the range that was stated.
By their numbers in this assay, from the lowest: compound 1; then compound 4; then compound 3. At a limit, above all of these: compound 2.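

The same atoms joined differently are enough to register in this assay: a 2.5-fold lower number from compound 3 to compound 4 (0.40 log units; beyond the scatter), a modest step in which 1-hydroxyethyl, with 1 hydrogen-bond donor, gives way to methoxymethyl, with 0. The clearest new reading is a single methyl placed on the oxygen of compound 1, which gives a 100-fold higher number from compound 1 to compound 4 (2.00 log units; beyond the scatter), so this position has now lost much of its activity with a methyl on the chain carbon and with one on the oxygen, and compound 4 recovers only a small part of that loss. Compound 2 reads only a limit, so an at least 3.9-fold lower number from compound 2 to compound 4 (0.59 log units; beyond the scatter) gives a floor for this step and not its full size: the limit of > 31600 nM in this assay, at which 1 of the 4 values shown sits.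

Compound 3 has a hydrogen-bond donor and compound 4 has none, yet both stand far above compound 1, so these compounds cannot show what makes the hydroxymethyl group of compound 1 so much better than its relatives. On these data alone, it remains open whether an aminomethyl group, a carboxylic acid or a small amide on this aromatic carbon could come close to compound 1.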